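Three Full Agonists and a Change at the Ring Nitrogen

This account rests on a few compounds, and the source may have more. Where it says the series, first, only, none or still open, it means among the compounds named here.

Compound 1, `CC(C)(C)OC(=O)N1CCC(O[C@H]2CC[C@H](Oc3ccc(S(C)(=O)=O)c(F)c3)CC2)CC1`, gives 106% in a functional assay on isolated protein for agonist activity at Glucose-dependent insulinotropic receptor (Homo sapiens), read by HTRF and cAMP accumulation; a lower number here means a smaller maximal response, a higher number a larger maximal response.
Compound 2, `CC(C)OC(=O)N1CCC(O[C@H]2CC[C@H](Oc3ccc(S(C)(=O)=O)nc3)CC2)CC1`, gives 101% in this assay.
Compound 3, `C[C@@H](CF)OC(=O)N1CCC(O[C@H]2CC[C@H](Oc3cnc(S(C)(=O)=O)cn3)CC2)CC1`, gives 105% in this assay.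

All three values sit close together, each reaching about the full response of the reference. Compound 3 stands among them: its nearest neighbour is compound 1, one point higher, and its furthest is compound 2, four points lower, both gaps within the usual scatter of this kind of measurement.

Compound 4, `CS(=O)(=O)c1cnc(O[C@H]2CC[C@H](OC3CCN(CC4(C(F)(F)F)CC4)CC3)CC2)cn1`, is not yet measured. It differs from compound 3 in one place: a group of 8 heavy atoms (5 carbon, 3 fluorine; one three-membered non-aromatic ring of carbon only) in place of a group of 7 heavy atoms (4 carbon, 2 oxygen, 1 fluorine; no ring), on an amine nitrogen in a ring

With every measured compound giving a full maximal response, no step beyond the scatter is expected in this assay from this change; the step of a number 5 percentage points lower from compound 3 to compound 4 (within the scatter) is expected to stay within scatter. Compound 4 is therefore estimated at 100%, in a range from 85% to 115%.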

Compound 4, largest response reached (Emax), in percent of the reference or control that the assay uses: 116%
Compound 4: middle estimate off by 16 percentage points, on the low side, and the stated range ends below it.
By their numbers in this assay, from the lowest: compounds 2, 3, 1 and 4 (each within the scatter of the next, the first and the last beyond it).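

Placing (1-(trifluoromethyl)cyclopropyl)methyl on the amine nitrogen in a ring, where a group with two hydrogen-bond acceptors stood, gives a number 11 percentage points higher from compound 3 to compound 4 (beyond the scatter) in this assay. A group with no hydrogen-bond acceptors at this nitrogen therefore keeps the full response, and this position can move the maximal response beyond the scatter. Nothing available here explains that rise.

The compounds shown leave open whether the three-membered ring, the trifluoromethyl or both matter. A plain cyclopropylmethyl or a simple ethyl on this nitrogen would help separate them.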